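A few compounds are considered here, and "the series" means these few. Any claim that something is new, unique, unknown or untested is made for them only; others in the source may bear on it.

Compound 1 `Cc1cc2c(cc1Cc1ccc(C(=O)NC[C@H]3CC[C@H](C(=O)O)CC3)o1)C(C)(C)CCC2(C)C` was measured in an assay on isolated protein for binding affinity to Gonadotropin-releasing hormone receptor (Rattus norvegicus) (on this read-out higher numbers stand for weaker inhibition and lower numbers for stronger inhibition), where compound 1 gives 3000 nM. Among the compounds with values here, of the two compounds measured so far this is the highest number, which here means the weaker binding. The other measured compound, compound 2 `Cc1cc2c(cc1Cc1ccc(C(=O)NCC3CCC(CNCc4cc(O)nc(O)n4)CC3)o1)C(C)(C)CCC2(C)C`, carries a larger nitrogen-containing extension on the amide side of the shared core, and in this assay compound 2 gives 865 nM, a lower number that lies beyond the usual scatter of repeated runs.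

Compound 3 `Cc1cc2c(cc1Cc1ccc(C(=O)NCC3CCN(C(=N)N)CC3)o1)C(C)(C)CCC2(C)C` has not yet been measured. It differs from compound 1 in one place: a group of 9 heavy atoms (6 carbon, 3 nitrogen; one six-membered non-aromatic ring with 1 hetero atom) in place of a group of 9 heavy atoms (7 carbon, 2 oxygen; one six-membered non-aromatic ring of carbon only), on a saturated chain carbon bound to an amide-type nitrogen. Within the data shown here, no measured pair shows this exact change, so its effect can only be estimated. A modest move toward a lower number is expected in this assay, because compound 2 gives 865 nM with a different nitrogen-containing group in place of the carboxycyclohexyl. For compound 3 the expected value is 700 nM, likely between 150 nM and 3000 nM. The expected step is a 4.3-fold lower number from compound 1 to compound 3 (0.63 log units; beyond the scatter).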

Compound 3, inhibition constant: 2040 nM
Beside the measured number, compound 3's estimate is 2.9-fold (0.46 log units) below it, within the range that was stated.
By their numbers in this assay, from the lowest: compound 2; then compounds 3 and 1 (each within the scatter of the next).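

In this assay, replacing the 4-carboxycyclohexyl group with a six-membered non-aromatic ring group of 6 carbon and 3 nitrogen atoms, on a saturated chain carbon bound to an amide-type nitrogen, gives a 1.5-fold lower number from compound 1 to compound 3 (0.17 log units; within the scatter). This exchange therefore removes the carboxylic acid without a change in the number beyond the scatter, so in this pair the acid is not needed to keep the binding seen for compound 1. Nothing measured here explains why the two groups read alike. Still open, on these data alone, is whether a plain amine on the ring would also read alike. A longer chain between the amide nitrogen and the ring could also shift the number, and these compounds cannot show whether it would.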